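The source may hold more compounds than are shown below. What is called first, only, known or untested is meant among the compounds shown, and "the series" means these compounds.

In an ADME assay on C8166 cells (Homo sapiens) for cytotoxicity, read by MTT assay (a lower number here means that less compound is tolerated, a higher number that more compound is tolerated), compound 1 `Cc1cc(S(N)(=O)=O)ccc1NC(=O)COc1ccc(F)cc1Oc1ccc2ccccc2c1` gives 68600 nM. On the bare numbers this is the largest of the three values measured, yet neither of the two other compounds is separated from it by more than the usual scatter. Compound 2 `Cc1cc(S(N)(=O)=O)ccc1NC(=O)COc1ccc(F)cc1Oc1ccc2ccccc2c1C`, which carries a methyl on the naphthalene ring, gives 56100 nM, and compound 3 `Cc1cc(S(N)(=O)=O)ccc1NC(=O)COc1ccc(F)cc1Oc1ccc2ccccc2c1Br`, which carries a bromo at the same place, gives 39500 nM. The change a 1.2-fold lower number from compound 1 to compound 2 (0.09 log units; within the scatter) and the change a 1.7-fold lower number from compound 1 to compound 3 (0.24 log units; within the scatter) both stay inside the scatter, as does a 1.4-fold lower number from compound 2 to compound 3 (0.15 log units; within the scatter).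

Compound 4 `Cc1cc(S(N)(=O)=O)ccc1NC(=O)COc1ccc(F)cc1Oc1ccc2ccccc2c1Cl` differs from compound 1 by chloro in place of hydrogen on an aromatic carbon. The two steps from compound 1 that put a group at this very place, a 1.2-fold lower number from compound 1 to compound 2 (0.09 log units; within the scatter) and a 1.7-fold lower number from compound 1 to compound 3 (0.24 log units; within the scatter), are the ones that bear on it, and both were too small to count. For this assay a step of a 1.4-fold lower number from compound 1 to compound 4 (0.14 log units; within the scatter) is therefore expected, that is, none beyond the scatter. Compound 4 is estimated at 50000 nM, with a likely range from 25000 nM to 100000 nM.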

Compound 4, half-maximal cytotoxic concentration: 47100 nM
For compound 4 the middle estimate is 1.1-fold (0.03 log units) above the measured one; the measured number falls inside the stated range.
By their numbers in this assay, from the lowest: compounds 3, 4, 2 and 1 (each within the scatter of the next).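

Chloro on this aromatic carbon gives a 1.5-fold lower number from compound 1 to compound 4 (0.16 log units; within the scatter), so it is the third group here, after methyl and bromo, that stays within the scatter of the unsubstituted compound in this assay. Exchanging one group for another at this place tells the same story, with a 1.2-fold higher number from compound 3 to compound 4 (0.08 log units; within the scatter) and a 1.2-fold lower number from compound 2 to compound 4 (0.08 log units; within the scatter), so the four compounds cannot be told apart in this measurement. No measurement at hand offers an explanation for this flat picture.

On these data alone, it remains open whether a quite different group at this place, such as an amine, a carboxylic acid or a longer carbon chain, would shift the number beyond the scatter. As far as these compounds go, it is also open whether chloro on another carbon of the same ring would leave the number just as unmoved.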